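Replacing the 3,4-dimethoxyphenyl group of compound 1

A few compounds are considered here, and "the series" means these few. Any claim that something is new, unique, unknown or untested is made for them only; others in the source may bear on it.

Measured in a functional assay on MCF7 cells (Homo sapiens) for inhibition, read by sulforhodamine B assay; on this read-out lower numbers stand for stronger inhibition of growth and higher numbers for weaker inhibition of growth:
Compound 1 `COc1ccc(-c2ccc(-c3ccc(-c4nc5cc(C)ccc5[nH]4)cc3)cc2)cc1OC`: 190 nM
Compound 2 `COc1cc(-c2ccc(-c3ccc(-c4nc5cc(C)ccc5[nH]4)cc3)cc2)cc(OC)c1OC`: 170 nM
Compound 3 `COc1ccc(-c2ccc(-c3ccc(-c4nc5ccccc5[nH]4)cc3)cc2)cc1OC`: 7600 nM

Compound 1 has one close neighbour and one distant one on these numbers. The close step is a 1.1-fold lower number from compound 1 to compound 2 (0.05 log units; within the scatter), and the distant step is a 40-fold higher number from compound 1 to compound 3 (1.60 log units; beyond the scatter).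

Compound 4 `Cc1ccc2[nH]c(-c3ccc(-c4ccc(-c5ccc(OC(F)(F)F)cc5)cc4)cc3)nc2c1` has not yet been measured in this assay. It keeps the rest of compound 1 and exchanges a single group: 4-(trifluoromethoxy)phenyl in place of 3,4-dimethoxyphenyl on an aromatic carbon.

Of the measured steps, the one that bears most directly is a 1.1-fold lower number from compound 1 to compound 2 (0.05 log units; within the scatter), a change on the same ring that stayed within the scatter. The large step, a 40-fold higher number from compound 1 to compound 3 (1.60 log units; beyond the scatter), removes a methyl that compound 4 retains, so it says little about this exchange, except that the methyl should stay favourable. For the measured compounds named here, no measured compound carries the entering group, so the guide is only partial and the range must stay wide. No shift beyond the scatter is expected in either direction, and the expected change is a 1.1-fold higher number from compound 1 to compound 4 (0.02 log units; within the scatter). For compound 4 the estimated value is 200 nM, with an expected range from 70 nM to 600 nM.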

Compound 4, concentration for 50% growth inhibition: 31000 nM
Compound 4: the middle estimate sits 160-fold (2.19 log units) below what was measured; the whole stated range lies below it.
By their numbers in this assay, from the lowest: compounds 2 and 1 (each within the scatter of the next); then compound 3; then compound 4.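

The exchange of 3,4-dimethoxyphenyl for 4-(trifluoromethoxy)phenyl in this assay gives a 160-fold higher number from compound 1 to compound 4 (2.21 log units; beyond the scatter), so this position is far from indifferent to what its ring carries. For the compounds shown here, the only earlier change on this ring, a 1.1-fold lower number from compound 1 to compound 2 (0.05 log units; within the scatter), had left the number within the scatter, and that step involved methoxy groups alone; the new result shows that the tolerance seen there does not extend to every substituted phenyl ring. Compound 4 also keeps the methyl whose removal accounts for a 40-fold higher number from compound 1 to compound 3 (1.60 log units; beyond the scatter), so keeping that methyl is not enough on its own to hold the number near that of compound 1, and nothing available explains why this exchange weakens growth inhibition so strongly.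

The single step changes two things together, the methoxy groups leaving and the trifluoromethoxy group entering, and the compounds shown cannot separate these two contributions. A plain phenyl, a 4-methoxyphenyl, or a ring carrying a hydroxyl or an amine at this place would be needed to show which of the two matters and how narrow the range of accepted groups really is.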